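Notes on a Methyl Step across Two Cores

The compounds below may be only part of what the source reports. "The series", "measured", "known", "first", "only" and "open" are said of these compounds alone.

Measured so far:
compound 1 `CN(C)C(=O)N(C)CC#CCn1ccnc1`: 11.8 mg/kg
compound 2 `Cc1cncn1CC#CCN(C)C(=O)N(C)C`: 9.7 mg/kg
compound 3 `Cn1ccn(CC#CCn2ccnc2)c1=O`: > 100 mg/kg

In a functional assay on the whole organism for antagonist activity, with Mus musculus as the target (a lower number here means that less compound is needed, a higher number that more compound is needed for the effect), compound 1 gives 11.8 mg/kg and compound 2 gives 9.7 mg/kg. The change between them is methyl in place of hydrogen on an aromatic carbon and the step it made is a 1.2-fold lower number from compound 1 to compound 2 (0.09 log units; within the scatter). For compound 3 the result in this assay is a limit, > 100 mg/kg, as noted in the limit of > 100 mg/kg in this assay, at which 1 of the 3 values shown sits. How the core of compound 3 differs from the core of compound 1 is not broken down here.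

Compound 4 `Cc1cncn1CC#CCn1ccn(C)c1=O` has not yet been measured in this assay. It differs from compound 3 by methyl in place of hydrogen on an aromatic carbon, the same kind of change as from compound 1 to compound 2, at a place described in the same words. The step that the limit leaves unreadable from compound 3 to compound 4 is what is expected, resting on the measured 1.2-fold lower number from compound 1 to compound 2 (0.09 log units; within the scatter). Compound 3 stands at a limit, so compound 4 is expected most likely to remain at or near that limit as well. For compound 4 the estimate is 120 mg/kg, with a range from 40 mg/kg to 300 mg/kg.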

Compound 4, dose for half-maximal effect: 8 mg/kg
Beside the measured number, compound 4's estimate is 15-fold (1.18 log units) above it, and the stated range ends above it.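

Carried from the core of compound 1 to the core of compound 3, methyl in place of hydrogen on an aromatic carbon does not keep its size in this assay: the same change on two cores in this assay, a 1.2-fold lower number (0.09 log units; within the scatter) from compound 1 to compound 2 and an at least 12-fold lower number (1.09 log units; beyond the scatter) from compound 3 to compound 4, at least 10-fold (1.01 log units) apart, beyond the scatter of two such steps. On the second core the change amounts to an at least 12-fold lower number from compound 3 to compound 4 (1.09 log units; beyond the scatter), whereas on the first core the step stays within the scatter, so a reading taken on one core gives no safe guide to the other. Going by these compounds alone, compound 3 stands at a limit of the assay, > 100 mg/kg, so the full size of that step remains unknown, and two cores show only that the step differs between them, not why it differs or how it would run on a third core.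

Left open is whether the drop in dose belongs to methyl specifically or would also follow from an ethyl or a chlorine at the same place on either core. Also open, from the compounds shown here alone, is whether a further core, for instance one carrying an amine, would behave like the core of compound 1 or like the core of compound 3 under this change.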